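Swapping Methyl for Bromo on a Short-Lived Compound

The source may report more compounds than this note shows. Statements on the series, on what has been measured and on what is new or still open speak of the compounds shown alone.

In a physicochemical assay for pharmacokinetics, read by HPLC, at pH 7.5, tested at 250 uM (on this read-out higher numbers stand for a longer-lived compound and lower numbers for a shorter-lived compound), compound 1 (`CN(C)CC1CCc2sccc2C1=O`) gives 116 h while compound 2 (`CN(C)CC1Cc2ccccc2C1=O`) gives only 0.167 h by comparison. Compound 3 (`Cc1ccc2c(c1)CC(CN(C)C)C2=O`) gives 0.4 h as the second highest of the three numbers and lies far nearer to compound 2 than to compound 1. Compound 4 (`CN(C)CC1Cc2cc(Br)ccc2C1=O`) is still unmeasured and differs from compound 3 by bromo in place of methyl on an aromatic carbon. Going by the values given here, the only measured step bearing on this change is a 2.4-fold higher number from compound 2 to compound 3 (0.38 log units; beyond the scatter) and it is modest. Among the compounds with values here, no bromo compound has been measured, so that step alone sets the expected size. A similarly modest drop in this assay is therefore expected, with a 2.0-fold lower number from compound 3 to compound 4 (0.30 log units; within the scatter) as the estimated step. The expected value for compound 4 is 0.2 h with an estimated range of 0.08 h to 0.5 h for now.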

Compound 4, half-life: 0.1 h
The estimate for compound 4 lay 2.0-fold (0.30 log units) above the measured number, and the stated range covers the measured number.
By their numbers in this assay, from the lowest: compounds 4 and 2 (each within the scatter of the next); then compound 3; then compound 1.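

In this assay the exchange of methyl for bromo on this aromatic carbon gives a 4.0-fold lower number from compound 3 to compound 4 (0.60 log units; beyond the scatter) and so separates the two groups at this position. Bromo in place of hydrogen gives a 1.7-fold lower number from compound 2 to compound 4 (0.22 log units; within the scatter) and so leaves bromo indistinguishable from hydrogen here, while methyl stands apart from both. No available evidence bears on what lies behind these numbers.

Going by these compounds, it remains open whether another group on this carbon, such as an amine, a carboxylic acid or a longer chain, would shift the half-life further. On these data alone, whether bromo would act alike on the core of compound 1 also stays open.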